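Swapping methyl for trifluoromethoxy on compound 1

This account rests on a few compounds, and the source may have more. Where it says the series, first, only, none or still open, it means among the compounds named here.

Measured compounds:
- compound 1, `COc1cc(-n2ncnc2-c2ccc(C)cc2)cc(OC)c1OC`: 1100 nM
- compound 2, `COc1cc(-c2ncnn2-c2ccc(Cl)cc2Cl)cc(OC)c1OC`: > 10000 nM
- compound 3, `COc1cc(-c2ncnn2-c2cccc(N)c2)cc(OC)c1OC`: > 10000 nM

For the measured compounds named here, in a functional assay on A549 cells (Homo sapiens) for antiproliferative activity, read by MTT assay, with a stated time of 72 h (a higher number here means a weaker inhibitor, a lower number a stronger inhibitor), compound 1 gives 1100 nM, and this is the only actual number among the three results. For compound 2 the result is a limit of the assay, > 10000 nM, not a number. For compound 3 the result is likewise a limit, > 10000 nM. Going by the values given here, the one step between measured compounds, a step that the two limits leave unreadable from compound 2 to compound 3, is therefore unreadable in size, and it concerns a change on an aromatic nitrogen, not the change considered here.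

The unmeasured compound 4, `COc1cc(-n2ncnc2-c2ccc(OC(F)(F)F)cc2)cc(OC)c1OC`, differs from compound 1 in one place: trifluoromethoxy in place of methyl on an aromatic carbon. Among the compounds with values here, no measured step bears on this exchange, so the expectation rests on compound 1 alone: the step of a 1.4-fold higher number from compound 1 to compound 4 (0.13 log units; within the scatter) is estimated to stay within the usual scatter, with a wide range to reflect that two of three results sit at the limit of > 10000 nM in this assay, at which 2 of the 3 values shown sit. Compound 4 is thus expected to give about 1500 nM, between 400 nM and 6000 nM.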

Compound 4, half-maximal inhibitory concentration: > 10000 nM
Compound 4 gave a limit, no number; the forecaster's own chance of this, stated with the estimate: 15%; at least 6.6-fold (0.82 log units) between middle value and limit.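

For the compounds shown here, the position on the aromatic carbon para to a large group, which no earlier step touched, turns out not to be indifferent to what sits there: in this assay, trifluoromethoxy in place of methyl gives an at least 9.0-fold higher number from compound 1 to compound 4 (0.95 log units; beyond the scatter). Compound 4 returns a limit of the assay rather than a number, so this step gives only the smallest possible size of the loss, and the true loss could be larger: the limit of > 10000 nM in this assay, at which 3 of the 4 values shown sit. Compound 1 therefore remains the only compound shown with a number, and its activity is now known to depend on the group at this position, since this single exchange takes the result out of the measurable range.

One exchange cannot separate the possible sources of the loss, as the entering group differs from methyl both in size, with 5 heavy atoms against 1 heavy atom, and in carrying oxygen and fluorine. From the compounds shown here alone, it remains open how an ethyl group, a single fluorine or an amine on the same carbon would behave, and so how narrow the range of groups tolerated at this position really is.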